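Swapping an aminobenzyl for a cyanobenzyl: expected cell toxicity

The source may report more compounds than this note shows. Statements on the series, on what has been measured and on what is new or still open speak of the compounds shown alone.

Compound 1 `COC(=O)c1ccc(NCc2cncn2Cc2ccccc2N)cc1-c1ccccc1` is one of three compounds tested in a toxicity assay on NIH3T3 cells (Mus musculus) for cytotoxicity, read by resazurin assay; on this read-out lower numbers stand for an effect already at smaller amounts and higher numbers for an effect only at larger amounts of compound. In this assay, among the compounds with values here, compound 1 gives 25000 nM, and among the three results it is the only one reported as a number. Compound 2 `c1ccc(-c2ccc(Cn3cncc3CNc3ccc(-c4nc5ccccc5s4)c(-c4ccccc4)c3)cc2)cc1` in this assay reaches only a limit of the assay, > 1000 nM, which is the limit of > 1000 nM in this assay, at which 1 of the 3 values shown sits. Compound 3 `c1ccc(-c2ccc(Cn3cncc3CNc3ccc(-c4ccc[nH]4)c(-c4ccccc4)c3)cc2)cc1` in this assay likewise stops at a limit of the assay, > 10000 nM, which is the limit of > 10000 nM in this assay, at which 1 of the 3 values shown sits. Within the data shown here, the one measured step, a step that the two limits leave unreadable from compound 2 to compound 3, has a limit at both ends and so cannot be read, and it concerns a different part of the shared core than the change considered here.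

Compound 4 `COC(=O)c1ccc(NCc2cncn2Cc2cccc(C#N)c2)cc1-c1ccccc1` is not yet measured. It differs from compound 1 in one place: 3-cyanophenyl in place of 2-aminophenyl on a saturated chain carbon bound to an aromatic nitrogen; cut one bond further out, the change reads 2-aminobenzyl to 3-cyanobenzyl. Among the measured compounds shown here, no measured step touches this part of the molecule, so the data give no direction to expect, and the step is expected to stay within the scatter, no change at the digits printed from compound 1 to compound 4 (within the scatter). Compound 4 is accordingly estimated at 25000 nM in this assay, with a range from 8000 nM to 80000 nM, and with a real chance that the assay again reports only a limit.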

Compound 4, half-maximal effective concentration: > 10000 nM
Compound 4: a limit, no number; the forecaster's own chance of this, stated with the estimate: 35%; the middle value is on the limit's open side.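

In this assay compound 4 gives > 10000 nM, which is a limit of the assay and not a number, so the change from compound 1 to compound 4 cannot be read as a step. The compounds shown leave open whether 2-aminobenzyl to 3-cyanobenzyl shifts cell toxicity at all, and if so, in which direction and how far.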